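From Acetylpiperidine to Dimethylpyrazole: A Step Bounded by Limits

The source may report more compounds than this note shows. Statements on the series, on what has been measured and on what is new or still open speak of the compounds shown alone.

Compounds measured in a physicochemical assay for solubility, read by LC-MS, in phosphate buffer, with a stated time of 24 h, at pH 7.4; on this read-out lower numbers stand for lower solubility and higher numbers for higher solubility:
- compound 1 `Cn1nccc1-c1cnc(NCc2c(F)ccc3c2CCO3)c2cn[nH]c(=O)c12`: 2000 nM
- compound 2 `O=C1CCCN1c1cnc(NCc2c(F)ccc3c2CCO3)c2cn[nH]c(=O)c12`: < 2000 nM (a limit)
- compound 3 `CC(=O)N1CCC(c2cnc(NCc3c(F)ccc4c3CCO4)c3cn[nH]c(=O)c23)CC1`: < 2000 nM (a limit)

Compound 3 has no number, only the limit < 2000 nM. It shares this position with compound 2, as the limit of < 2000 nM in this assay, at which 2 of the 3 values shown sit, shows.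

Compound 4 `Cc1cc(-c2cnc(NCc3c(F)ccc4c3CCO4)c3cn[nH]c(=O)c23)n(C)n1` is the next to be read. Its change from compound 3 is 1,3-dimethyl-1H-pyrazol-5-yl in place of 1-acetylpiperidin-4-yl on an aromatic carbon.

The measured step that bears most directly is a number no higher from compound 1 to compound 3 (the limit leaves the size open), which brings in 1-acetylpiperidin-4-yl in place of 1-methyl-1H-pyrazol-5-yl. Its size cannot be read, and the same holds for a number no higher from compound 1 to compound 2 (the limit leaves the size open). Compound 1 carries the pyrazole closest by name to the entering group, so a reading near its 2000 nM is expected. For compound 4, a further limit would be no surprise. In this assay, the expected step is a number no lower from compound 3 to compound 4 (the limit leaves the size open), upward if it shows at all. For compound 4 the estimate is 2000 nM, with an expected range from 700 nM to 5000 nM.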

Compound 4, solubility: 1000 nM
Estimate against measurement, compound 4: 2.0-fold (0.30 log units) above; the measured number falls inside the stated range.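

Among the compounds shown here, the one readable step, a 2.0-fold lower number from compound 1 to compound 4 (0.30 log units; within the scatter), shows that methyl in place of hydrogen on the pyrazole of compound 1 gives no difference that can be told from scatter in this assay. For the compounds shown here, this position now carries two pyrazoles with actual numbers, where the earlier compounds offered only one. The steps from compound 2 and compound 3 to compound 4 cannot be read, and both of those compounds remain limits, not numbers: the limit of < 2000 nM in this assay, at which 2 of the 4 values shown sit.

The compounds shown leave open what numbers stand behind those two limits, and so whether the pyrazoles differ at all from the 2-oxopyrrolidin-1-yl and 1-acetylpiperidin-4-yl groups. They also leave open how an amine or a carboxylic acid on this aromatic carbon would read in this assay.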